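Swapping one aromatic group on the shared core

The source may hold more compounds than are shown below. What is called first, only, known or untested is meant among the compounds shown, and "the series" means these compounds.

In a functional assay on MCF7 cells (Homo sapiens) for cytotoxicity, read by MTT assay, with a stated time of 24 h (on this read-out lower numbers stand for stronger inhibition and higher numbers for weaker inhibition), compound 1 (`CCc1cc(Br)ccc1Nc1ncnc2cc(OC)c(OCCCSc3nc4ccccc4s3)cc12`) gives 5870 nM and compound 2 (`CCCCc1nc(Cl)c(C=O)n1CCCOc1cc2c(Nc3ccc(F)c(Cl)c3)ncnc2cc1OC`) gives 5020 nM while compound 3 (`CCCCc1nc(Cl)c(C=O)n1CCCOc1cc2c(Nc3ccc(Br)cc3CC)ncnc2cc1OC`) gives 6560 nM so compound 3 stands level with both others, its gaps to them lying within the scatter. Compound 4 (`CCCCc1nc(Cl)c(C=O)n1CCCOc1cc2c(Nc3cccc(I)c3)ncnc2cc1OC`) has yet to be measured. It carries 3-iodophenyl in place of 4-bromo-2-ethylphenyl on a nitrogen on an aromatic ring. Among the measured compounds shown here, two measured steps bear on this change. Exchanging the group on that same nitrogen gave a 1.3-fold higher number from compound 2 to compound 3 (0.12 log units; within the scatter) and exchanging the group on the saturated chain gave a 1.1-fold higher number from compound 1 to compound 3 (0.05 log units; within the scatter) so neither moved the number beyond the scatter. For the measured compounds named here, no measured compound carries 3-iodophenyl, which leaves some room for surprise. The expected step in this assay is therefore a 1.1-fold lower number from compound 3 to compound 4 (0.05 log units; within the scatter) with no direction favoured and nothing expected beyond the scatter. For compound 4 the estimated value is 5800 nM with an expected range from 2600 nM to 13000 nM in this test.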

Compound 4, half-maximal inhibitory concentration: 3000 nM
The estimate for compound 4 lay 1.9-fold (0.29 log units) above the measured number; the measured number falls inside the stated range.
By their numbers in this assay, from the lowest: compounds 4, 2, 1 and 3 (each within the scatter of the next, the first and the last beyond it).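

In this assay, among the compounds shown here, putting 3-iodophenyl in place of 4-bromo-2-ethylphenyl on the nitrogen gives a 2.2-fold lower number from compound 3 to compound 4 (0.34 log units; beyond the scatter) and this modest drop is the first step at this position to clear the scatter. Measured against 3-chloro-4-fluorophenyl on the same nitrogen, 3-iodophenyl gives a 1.7-fold lower number from compound 2 to compound 4 (0.22 log units; within the scatter) so the gain is clear only against 4-bromo-2-ethylphenyl. No measurement here explains why the number fell.

The change removes bromine and ethyl and adds iodine in a single step, so the compounds shown cannot tell which of these parts matters. Still open, from the compounds shown here alone, is how a plain phenyl or a 3-bromophenyl would compare on that nitrogen, and whether 3-iodophenyl gives a similar step when paired with the (1,3-benzothiazol-2-yl)sulfanyl chain of compound 1.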